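Replacing carboxy with hydroxymethyl in compound 1

The compounds below may be only part of what the source reports. "The series", "measured", "known", "first", "only" and "open" are said of these compounds alone.

In a functional assay on ZR-75-1 cells (Homo sapiens) for cytotoxicity, read by sulforhodamine B assay, with a stated time of 3 days (on this read-out lower numbers stand for an effect already at smaller amounts and higher numbers for an effect only at larger amounts of compound), compound 1 (`COc1c(-c2occ(C)c2C(=O)O)ccc2c1CCCC2(C)C`) gives 41.4 uM and compound 3 (`Cc1coc(-c2ccc3c(c2O)CCC3)c1C(=O)O`) gives 30.2 uM, two values within the usual scatter of each other. Compound 2 (`CCc1cccc2c(O)c(-c3occ(C)c3C(=O)O)ccc12`) gives 1 uM, a far lower number than either, so compound 1 stands at the weak end of this small set. Compound 4 (`COc1c(-c2occ(C)c2CO)ccc2c1CCCC2(C)C`) has hydroxymethyl in place of carboxy on an aromatic carbon. All three measured compounds carry carboxy, so none of them shows what losing it does. Only a small expected step in this assay, leaning toward a lower number and not beyond the scatter, seems reasonable: a 1.7-fold lower number from compound 1 to compound 4 (0.22 log units; within the scatter). For compound 4 the estimated value is 25 uM, with an expected range from 8 uM to 80 uM.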

Compound 4, concentration for half-maximal effect: 15 uM
For compound 4 the middle estimate is 1.7-fold (0.22 log units) above the measured one; the range from low to high includes it.
By their numbers in this assay, from the lowest: compound 2; then compounds 4, 3 and 1 (each within the scatter of the next, the first and the last beyond it).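

In this assay, hydroxymethyl in place of carboxy on this aromatic carbon brings a 2.8-fold lower number from compound 1 to compound 4 (0.44 log units; beyond the scatter), a modest step but beyond the scatter. On the core of compound 1, then, carboxy at this position is not needed for the cytotoxic effect, and the number falls without it. Nothing available explains this shift.

As far as these compounds go, whether an aminomethyl group or a methyl ester at this position would lower the number further remains open. So does whether the same change would have a similar effect on the core of compound 2.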